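Removing the 4-methoxybenzyl from the pyrazole nitrogen of compound 1

The source may report more compounds than this note shows. Statements on the series, on what has been measured and on what is new or still open speak of the compounds shown alone.

Compound 1 `COc1ccc(Cn2nc(-c3ccccc3)c3cc(C(=N)Nc4cccc(C(F)(F)F)c4)nc(Nc4cc(OC)c(OC)c(OC)c4)c32)cc1` has no single number in a functional assay on PC-3 cells (Homo sapiens) for cytotoxicity, read by MTT assay, with a stated time of 72 h; a higher number here means a weaker inhibitor, a lower number a stronger inhibitor; its value there is recorded as "not determined" (no result reported), so it gives no anchor for the series. Compound 4 `COc1cc(Nc2nc(C(=N)Nc3cccc(C(F)(F)F)c3)cc3c(-c4ccccc4)n[nH]c23)cc(OC)c1OC` differs from it only in one place: hydrogen in place of 4-methoxybenzyl on an aromatic nitrogen.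

Among the measured compounds shown here, the only measured step that touches this kind of change runs the other way. Compound 2 `CN1CCN(c2ccc(NC(=N)c3cc4cnn(C)c4cn3)cc2)CC1` gives 32300 nM in this assay, and compound 3 `COc1ccc(Cn2ncc3cc(C(=N)Nc4ccc(N5CCN(C)CC5)cc4)ncc32)cc1` gives 6100 nM; the step of a 5.3-fold lower number from compound 2 to compound 3 (0.72 log units; beyond the scatter) shows that adding the 4-methoxyphenyl to the saturated chain carbon bound to the aromatic nitrogen lowered the number. Read in reverse, taking the 4-methoxybenzyl off the aromatic nitrogen of compound 1 would be expected to raise the number in this assay by a similar modest amount, beyond the scatter, though compound 1 itself carries a phenyl group and a trimethoxyanilino group that compounds 2 and 3 lack, and no step from compound 1 exists to check against.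

With no value for compound 1, the estimate for compound 4 is anchored only on the range spanned by compound 2 and compound 3, shifted upward: compound 4 is expected to give about 20000 nM in this assay, within 3000 nM to 100000 nM.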

Compound 4, half-maximal inhibitory concentration: 13900 nM
The estimate for compound 4 lay 1.4-fold (0.16 log units) above the measured number; measured number inside the range.
By their numbers in this assay, from the lowest: compound 3; then compound 4; then compound 2.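

No step can be read from compound 1 to compound 4, as compound 1 has no single number in this assay. The compounds shown leave open how far, and in which direction, hydrogen in place of 4-methoxybenzyl on the aromatic nitrogen moves the number on the core of compound 1. Nothing at hand explains the value of compound 4.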